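The source may report more compounds than this note shows. Statements on the series, on what has been measured and on what is new or still open speak of the compounds shown alone.

Measured so far in a functional assay on HEK293 cells for agonist activity at Neuronal acetylcholine receptor; alpha3/beta4 (Homo sapiens), read by FLIPR; a higher number here means that more compound is needed for the effect, a lower number that less compound is needed: compound 1 `N#Cc1cncc(N2CC[C@@H]3CN[C@@H]3C2)c1` gives 490 nM; compound 2 `COc1cncc(N2CC[C@@H]3CN[C@@H]3C2)c1` gives 4500 nM; compound 3 `COc1cc(N2CC[C@H]3CN[C@H]3C2)cnc1Br` gives 8 nM.

Compound 3 gives the lowest of the three numbers in this assay, well beyond the scatter from both others. Compound 1 and compound 2 share a core and differ in one place, (cyano in place of methoxy on an aromatic carbon), and that change gave a 9.2-fold lower number from compound 2 to compound 1 (0.96 log units; beyond the scatter). Compound 3 and compound 2 differ in more than one place, so the difference between the two cores is not broken down here.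

Compound 4 `N#Cc1cc(N2CC[C@H]3CN[C@H]3C2)cnc1Br` has not yet been measured in this assay. It differs from compound 3 by cyano in place of methoxy on an aromatic carbon. For the measured compounds named here, this is the same kind of change as that from compound 2 to compound 1, not the same change: in compound 3 the place is ortho to a bromo group, which has no counterpart in compound 2. Compound 4 is expected to show a step of a 4.0-fold lower number from compound 3 to compound 4 (0.60 log units; beyond the scatter) in this assay, an expectation resting on the step of a 9.2-fold lower number from compound 2 to compound 1 (0.96 log units; beyond the scatter) and tempered by the different surroundings. The estimate for compound 4 is 2 nM, from 0.5 nM to 10 nM.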

Compound 4, half-maximal effective concentration: 4.4 nM
Compound 4: middle estimate off by 2.2-fold (0.34 log units), on the low side, within the range that was stated.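

In this assay, cyano in place of methoxy on an aromatic carbon gives a 1.8-fold lower number from compound 3 to compound 4 (0.26 log units; within the scatter), so on this core the change has no effect that can be told apart from the scatter of repeated measurements. The change therefore did not carry over at the same size from one core to the other: the same change on two cores in this assay, a 9.2-fold lower number (0.96 log units; beyond the scatter) from compound 2 to compound 1 and a 1.8-fold lower number (0.26 log units; within the scatter) from compound 3 to compound 4, 5.1-fold (0.70 log units) apart, beyond the scatter of two such steps This shows that, in these two pairs, a step measured on one core cannot be transferred to the other at face value, but it does not show which difference in the surroundings is responsible, since the bromo group and the remainder of the core vary together, and two pairs establish no general rule.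

The compounds shown leave open whether the step would stay this small with the bromo group removed from the core of compound 3 or replaced by a chloro or methyl group. They also leave open how an amine or a carboxylic acid would behave at the place held by cyano and methoxy.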